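A few compounds are considered here, and "the series" means these few. Any claim that something is new, unique, unknown or untested is made for them only; others in the source may bear on it.

In a functional assay on THP-1 cells (Homo sapiens) for inhibition, read by sulforhodamine B assay, with a stated time of 48 h, tested at 50 uM (a lower number here means less inhibition of growth, a higher number more inhibition of growth at the concentration tested), compound 1 (`COc1cc(/C=C/C(=O)/C=C/c2cccc3ccccc23)ccc1OCc1cn(CCOc2cc(=O)oc3ccccc23)nn1`) gives 89% and compound 2 (`COc1cc(/C=C/C(=O)/C=C/c2ccccc2)ccc1OCc1cn(CCOc2cc(=O)oc3ccccc23)nn1`) gives 61% and so holds the lower of the two numbers. Compound 3 (`COc1cc(/C=C/C(=O)/C=C/c2ccco2)ccc1OCc1cn(CCOc2cc(=O)oc3ccccc23)nn1`) departs from compound 2 by a single exchange (furan-2-yl in place of phenyl on a double-bonded chain carbon bound to a double-bonded chain carbon) on the chain carbon concerned. Among the measured compounds shown here, only one measured step bears on this, made at the same place (a number 28 percentage points lower from compound 1 to compound 2 (beyond the scatter)) and lying beyond the scatter. Given that step alone, a smaller fall in this assay is expected (a number 6 percentage points lower from compound 2 to compound 3 (within the scatter)) and it may stay within the scatter. Compound 3 is estimated at 55% with an expected range of 35% to 75% for this measurement.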

Compound 3, percent growth inhibition at one concentration: 78%
Estimate against measurement, compound 3: 23 percentage points below, outside the stated range (above it).
By their numbers in this assay, from the lowest: compound 2; then compound 3; then compound 1.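

In this assay, the number at this chain carbon does not simply fall as the ring gets smaller: furan-2-yl, with 5 heavy atoms including 1 oxygen against the 6 carbon atoms of phenyl, brings a number 17 percentage points higher from compound 2 to compound 3 (beyond the scatter). Naphthalen-1-yl still stands on top, with a number 11 percentage points lower from compound 1 to compound 3 (beyond the scatter). Nothing given here accounts for this order.

The compounds shown leave open whether thiophen-2-yl, the sulfur counterpart of furan-2-yl, would match it at this carbon. They also leave open what a dimethylamino group or a carboxylic acid on the phenyl ring would do.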